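From 2,4-dichlorophenyl to 4-hydroxyphenyl in compound 3

This account rests on a few compounds, and the source may have more. Where it says the series, first, only, none or still open, it means among the compounds named here.

Compound 1 `CC/C(=C(/c1ccc(NC(=O)C(C)C)cc1)c1ccc(OC)cc1)c1ccc(O)cc1` gives 5800 nM
Compound 2 `CC/C(=C(\c1ccccc1)c1ccc(NC(=O)C(C)C)cc1)c1ccc(Cl)cc1Cl` gives 3300 nM

In a functional assay on HeLa cells (Homo sapiens) for inhibition, read by trypan blue exclusion, with a stated time of 72 h (on this read-out higher numbers stand for weaker inhibition of growth and lower numbers for stronger inhibition of growth), compound 2 at 3300 nM and compound 1 at 5800 nM lie within the usual scatter of each other. Compound 3 `CC/C(=C(\c1ccccc1)c1ccc(NC(=O)C(C)C)cc1)c1ccc(O)cc1` differs from compound 2 in one place, with 4-hydroxyphenyl in place of 2,4-dichlorophenyl on a double-bonded chain carbon bound to a double-bonded chain carbon and a saturated chain carbon. Going by the values given here, no measured pair shows this change alone. Compound 1 also carries 4-hydroxyphenyl at that place and gives 5800 nM in this assay so no step beyond the scatter is expected. The estimated step is small (a 1.2-fold higher number from compound 2 to compound 3 (0.08 log units; within the scatter)). For compound 3 the expected value is 4000 nM (estimated range 1800 nM to 9000 nM).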

Compound 3, concentration for 50% growth inhibition: 3800 nM
Compound 3: the middle estimate sits 1.1-fold (0.02 log units) above what was measured, within the range that was stated.
By their numbers in this assay, from the lowest: compounds 2, 3 and 1 (each within the scatter of the next).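

In this assay the change from 2,4-dichlorophenyl to 4-hydroxyphenyl on this double-bonded chain carbon gives a step (a 1.2-fold higher number from compound 2 to compound 3 (0.06 log units; within the scatter)), so the two groups cannot be told apart at this position. Hydrogen in place of methoxy on an aromatic carbon gives a step (a 1.5-fold lower number from compound 1 to compound 3 (0.18 log units; within the scatter)), so that place also shows nothing beyond the scatter. No measurement offers an explanation for these close values.

As far as these compounds go, what an amine or a carboxylic acid would give on this double-bonded chain carbon stays open. So does whether any group there can move the number beyond the scatter.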